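Amide nitrogen variation in the stilbene pyridine ether series

The compounds below may be only part of what the source reports. "The series", "measured", "known", "first", "only" and "open" are said of these compounds alone.

Compound 3 `O=C(NC1CC1)c1cc(Oc2ccc(/C=C/c3ccncc3)cc2)ccn1` gives 35500 nM in a functional assay on A549 cells (Homo sapiens) for antiproliferative activity, read by CCK-8 assay, with a stated time of 48 h; a higher number here means a weaker inhibitor, a lower number a stronger inhibitor. Among the three measured compounds it holds the second highest number; compound 1 `COc1ccc(NC(=O)c2cc(Oc3ccc(/C=C/c4ccncc4)cc3)ccn2)cc1` gives 25600 nM, and compound 2 `O=C(Nc1ccc(Cl)cc1)c1cc(Oc2ccc(/C=C/c3ccncc3)cc2)ccn1` gives 62100 nM. Both neighbours sit within the scatter of compound 3, as a 1.4-fold higher number from compound 1 to compound 3 (0.14 log units; within the scatter) and a 1.7-fold lower number from compound 2 to compound 3 (0.24 log units; within the scatter) show. Within the data shown here, the only step beyond the scatter is the one on the aromatic carbon of the amide substituent, a 2.4-fold higher number from compound 1 to compound 2 (0.38 log units; beyond the scatter), which does not involve the position changed here.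

Compound 4 `O=C(c1cc(Oc2ccc(/C=C/c3ccncc3)cc2)ccn1)N1CCCC1` differs from compound 3 at the carbonyl carbon: pyrrolidin-1-yl in place of cyclopropylamino on a carbonyl carbon. The measured steps that bear on this change are the two that alter the group on the amide-type nitrogen, a 1.4-fold higher number from compound 1 to compound 3 (0.14 log units; within the scatter) and a 1.7-fold lower number from compound 2 to compound 3 (0.24 log units; within the scatter), both within the scatter. Among the measured compounds shown here, no measured compound carries a group without a hydrogen-bond donor at this position, so the expectation rests only on the small size of the nitrogen-side steps seen so far. A step within the scatter is therefore expected, a 1.1-fold higher number from compound 3 to compound 4 (0.05 log units; within the scatter), with no direction claimed. Compound 4 is estimated at 40000 nM, within 15000 nM to 110000 nM in this assay.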

Compound 4, half-maximal inhibitory concentration: 18600 nM
For compound 4 the middle estimate is 2.2-fold (0.33 log units) above the measured one; measured number inside the range.
By their numbers in this assay, from the lowest: compounds 4, 1, 3 and 2 (each within the scatter of the next, the first and the last beyond it).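

In this assay the position on the carbonyl carbon accepts a group without the amide hydrogen: pyrrolidin-1-yl in place of cyclopropylamino gives no step outside the scatter (a 1.9-fold lower number from compound 3 to compound 4 (0.28 log units; within the scatter)), and the same holds for pyrrolidin-1-yl in place of (4-methoxyphenyl)amino (a 1.4-fold lower number from compound 1 to compound 4 (0.14 log units; within the scatter)). Among these compounds, only the replacement of (4-chlorophenyl)amino gives a step beyond the scatter (a 3.3-fold lower number from compound 2 to compound 4 (0.52 log units; beyond the scatter)), and it is modest, so compound 2 is the one compound here set apart from compound 4, while all four numbers remain in the same broad range. Nothing available beyond these numbers bears on the reason for this result.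

The step from compound 3 to compound 4 changes the ring and removes the amide hydrogen together, so N-methyl-N-cyclopropylamino, which would lose the hydrogen and keep the three-membered ring, is what would separate the two changes. Also open, on these data alone, is how far this position stays flat with other groups on the carbonyl carbon, such as piperidin-1-yl, morpholin-4-yl or an open-chain dimethylamino.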